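Chloro-to-cyano exchange on a thiophene-bearing anilinothiazole

The compounds below may be only part of what the source reports. "The series", "measured", "known", "first", "only" and "open" are said of these compounds alone.

Measured in a functional assay on MT2 cells (Homo sapiens) for cytotoxicity, read by MTT assay; on this read-out lower numbers stand for higher toxicity in this test and higher numbers for lower toxicity in this test:
compound 1 `CC(C)=CCOc1cc(Nc2nccs2)ccc1Cl`: 26000 nM
compound 2 `CC(C)=CCOc1cc(Nc2nccs2)ccc1C#N`: 750 nM
compound 3 `Clc1ccc(Nc2nccs2)cc1OCc1ccsc1`: 38000 nM

Compound 2 and compound 1 differ by cyano in place of chloro on an aromatic carbon, and this gave a 35-fold lower number from compound 1 to compound 2 (1.54 log units; beyond the scatter). Compound 3 shares its core with compound 1 except for (thiophen-3-yl in place of 2-methylprop-1-en-1-yl on a saturated chain carbon bound to an oxygen on an aromatic ring); the resulting step, a 1.5-fold higher number from compound 1 to compound 3 (0.16 log units; within the scatter), is within the scatter, so the two are not distinguished here.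

Compound 4 `N#Cc1ccc(Nc2nccs2)cc1OCc1ccsc1` is the unmeasured analogue of compound 3 carrying (cyano in place of chloro on an aromatic carbon). It is the same kind of change as in compound 2, but the place differs: in compound 2 the cyano is ortho to a (3-methylbut-2-en-1-yl)oxy group, while in compound 4 it is ortho to a group of 7 heavy atoms. Among the measured compounds shown here, with only one earlier instance, the step is expected to be of similar size, a 35-fold lower number from compound 3 to compound 4 (1.54 log units; beyond the scatter), because compound 1 to compound 2 showed a 35-fold lower number from compound 1 to compound 2 (1.54 log units; beyond the scatter). For compound 4 in this assay the expected value is 1100 nM.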

Compound 4, half-maximal cytotoxic concentration: 1100 nM
Beside the measured number, compound 4's estimate shows no gap at the digits printed; low and high end bracket the measured number.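

In this assay, cyano in place of chloro on the core of compound 3 gives a 35-fold lower number from compound 3 to compound 4 (1.54 log units; beyond the scatter), and the step matches the one on the core of compound 1: the same change on two cores in this assay, a 35-fold lower number (1.54 log units; beyond the scatter) from compound 1 to compound 2 and a 35-fold lower number (1.54 log units; beyond the scatter) from compound 3 to compound 4, 1.0-fold (0.00 log units) apart, within the scatter of two such steps
Thiophen-3-yl in place of 2-methylprop-1-en-1-yl gives a 1.5-fold higher number from compound 2 to compound 4 (0.17 log units; within the scatter), which does not separate the two compounds, and the cyano pair repeats the chloro pair: the same change on two cores in this assay, a 1.5-fold higher number (0.16 log units; within the scatter) from compound 1 to compound 3 and a 1.5-fold higher number (0.17 log units; within the scatter) from compound 2 to compound 4, 1.0-fold (0.00 log units) apart, within the scatter of two such steps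
The two changes therefore carry over between these cores, but four compounds in one assay show neither why the cyano step is large nor how far it extends beyond this pair of cores.

Open, going by these compounds, is whether an amine or a carboxylic acid in place of the cyano would give a comparable number. Also open, on these data alone, is whether the step holds with a longer alkyl chain in place of the (3-methylbut-2-en-1-yl)oxy group.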